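The compounds below may be only part of what the source reports. "The series", "measured", "known", "first", "only" and "open" are said of these compounds alone.

In a functional assay on MDA-MB-231 cells (Homo sapiens) for inhibition, read by MTT assay, with a stated time of 72 h (a lower number here means a stronger inhibitor, a higher number a weaker inhibitor), compound 3 `CC1=NN(c2ccccc2)C(=O)[C@@]12C(=O)C=CC[C@H]2c1ccccc1` gives 5500 nM. This is within the scatter of compound 2 `CC1=NN(c2ccccc2)C(=O)[C@]12C(=O)C=CC[C@H]2c1ccccc1` at 5800 nM and of compound 1 `CC1=NN(c2ccccc2)C(=O)[C@]12C(=O)C=CC[C@@H]2c1ccc(C)cc1` at 6240 nM. Compound 4 `CC1=NN(c2ccccc2)C(=O)[C@]12C(=O)C=CC[C@@H]2c1ccccc1` has yet to be measured, and it relates to compound 3 as follows: the two compounds have the same atoms and bonds and differ only in configuration as drawn: 2 of 2 stereo elements differ (all stereocentres are inverted: mirror images); a stereocentre at a saturated ring carbon is drawn R in compound 3 and S in compound 4; a stereocentre at a saturated ring carbon is drawn S in compound 3 and R in compound 4. Going by the values given here, one measured step bears on this change, and it inverts a single stereocentre: a 1.1-fold lower number from compound 2 to compound 3 (0.02 log units; within the scatter). It comes with the fact that compounds 2 and 3 differ only in the configuration as drawn. No measured step inverts both stereocentres, so the evidence is only partial, but the small size of that step gives no reason to expect a shift in either direction. The expected step, none beyond the scatter, is a 1.1-fold higher number from compound 3 to compound 4 (0.02 log units; within the scatter). For compound 4 the estimated value is 5800 nM, with an expected range from 3500 nM to 9500 nM.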

Compound 4, half-maximal inhibitory concentration: 9080 nM
For compound 4 the middle estimate is 1.6-fold (0.19 log units) below the measured one, within the range that was stated.
By their numbers in this assay, from the lowest: compounds 3, 2, 1 and 4 (each within the scatter of the next).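

In this assay, inverting both stereocentres gives a 1.7-fold higher number from compound 3 to compound 4 (0.22 log units; within the scatter), so even the full mirror-image change stays within the scatter, and the only difference involved is this: the fact that compounds 3 and 4 differ only in the configuration as drawn Inverting the second stereocentre alone gives a 1.6-fold higher number from compound 2 to compound 4 (0.19 log units; within the scatter), so each stereocentre has now been inverted singly without a step beyond the scatter. Hydrogen in place of methyl on an aromatic carbon, with the configuration held, gives a 1.5-fold higher number from compound 1 to compound 4 (0.16 log units; within the scatter), also within the scatter.

The compounds shown leave open how an amine or a carboxylic acid in place of that methyl would read in this assay. They also leave open whether configuration would then count for more.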